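Thiophen-3-yl for Phenyl: Three Limits, One Expectation

This account rests on a few compounds, and the source may have more. Where it says the series, first, only, none or still open, it means among the compounds named here.

Compound 1 `O=c1[nH]cnc2c1c(-c1ccsc1)cn2[C@@H]1O[C@H](CO)[C@@H](O)[C@H]1O`: in a functional assay on K562 cells (Homo sapiens), read by MTT assay, with a stated time of 72 h (on this read-out lower numbers stand for stronger inhibition and higher numbers for weaker inhibition), compound 1 gives only a limit, > 20000 nM.
Compound 2 `O=c1[nH]cnc2c1c(-c1ccccc1)cn2[C@@H]1O[C@H](CO)[C@@H](O)[C@H]1O`: in this assay compound 2 gives only a limit, > 20000 nM.
Compound 3 `Nc1nc2c(c(-c3ccccc3)cn2[C@@H]2O[C@H](CO)[C@@H](O)[C@H]2O)c(=O)[nH]1`: in this assay compound 3 gives only a limit, > 20000 nM.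

None of the three measured compounds yields a number; every value is a limit of the assay, and that is the whole of the evidence so far: the limit of > 20000 nM in this assay, at which 3 of the 3 values shown sit. Compound 2 and compound 1 differ in one place, (thiophen-3-yl in place of phenyl on an aromatic carbon). The step that the two limits leave unreadable from compound 2 to compound 1 has no readable size, since both ends sit at the limit. Compound 3 carries a different core from compound 2; the counted difference is amino in place of hydrogen on an aromatic carbon. The step that the two limits leave unreadable from compound 2 to compound 3 is equally unreadable for the same reason.

Compound 4 `Nc1nc2c(c(-c3ccsc3)cn2[C@@H]2O[C@H](CO)[C@@H](O)[C@H]2O)c(=O)[nH]1` has not yet been measured. It differs from compound 3 by thiophen-3-yl in place of phenyl on an aromatic carbon. The surroundings of the place are the same, word for word, as in the change from compound 2 to compound 1, so this is the same change made on the other core.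

The expectation for compound 4 rests first on compound 3, whose value > 20000 nM is a limit. It rests second on the parallel step that the two limits leave unreadable from compound 2 to compound 1, which offered no readable size and gave no sign of the change moving a compound off the limit. Compound 4 is therefore expected to give 30000 nM, the expected step being a step that the limit leaves unreadable from compound 3 to compound 4, within a range from 10000 nM to 80000 nM.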

Compound 4, half-maximal inhibitory concentration: 18300 nM
The estimate for compound 4 lay 1.6-fold (0.21 log units) above the measured number, within the range that was stated.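

In this assay, putting thiophen-3-yl in place of phenyl on the core of compound 3 gives an at least 1.0-fold lower number from compound 3 to compound 4 (0.03 log units; that floor lies within the scatter), and adding the amino group to the core of compound 1 gives an at least 1.0-fold lower number from compound 1 to compound 4 (0.03 log units; that floor lies within the scatter); each is only a floor on a step, and neither floor shows a real difference. Among the compounds shown here, compound 4 is therefore the one compound here with a readable number, but that number does not show that thiophen-3-yl acts differently from phenyl, or that the amino group matters, as the true size of each step remains unknown. Nor does it show whether the change carries from one core to the other, since there is no readable step on the core of compound 2 to set against the new one, and every step with a limit at both ends stays unreadable: the limit of > 20000 nM in this assay, at which 3 of the 4 values shown sit.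

The compounds shown leave open whether any group at this place on an aromatic carbon can give a number clearly beyond the scatter from that of compound 4. An amine, a carboxylic acid or a longer chain in place of thiophen-3-yl would be one way to test this, and a second readable number on each core would allow the two steps to be compared directly.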